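The source may hold more compounds than are shown below. What is called first, only, known or untested is meant among the compounds shown, and "the series" means these compounds.

Measured so far: compound 1 `N#C/C(=C\N1CCN(C(=O)c2ccco2)C1=S)C(=O)Nc1ccc(Cl)cc1`, 17700 nM; compound 2 `N#C/C(=C\N1CCN(C(=O)c2ccco2)C1=S)C(N)=O`, 39800 nM, both in a functional assay on MOLT-4 cells (Homo sapiens) for inhibition, read by sulforhodamine B assay, with a stated time of 48 h; on this read-out lower numbers stand for stronger inhibition of growth and higher numbers for weaker inhibition of growth.

Compound 2 stands highest of the two numbers, reached by a 2.2-fold higher number from compound 1 to compound 2 (0.35 log units; beyond the scatter). Compound 3 `N#C/C(=C\N1CCN(C(=O)c2ccco2)C1=S)C(=O)c1ccccc1` differs from compound 2 by phenyl in place of amino on a carbonyl carbon. Going by the values given here, no measured step makes exactly this change. Among the compounds with values here, the only step to hand, a 2.2-fold higher number from compound 1 to compound 2 (0.35 log units; beyond the scatter), shows that taking an aryl group off the amide nitrogen raised the number modestly; a modest movement the other way is expected when a phenyl enters on the carbonyl carbon. Compound 3 is therefore expected at 20000 nM, range 7000 nM to 60000 nM, which is estimated as a 2.0-fold lower number from compound 2 to compound 3 (0.30 log units; within the scatter).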

Compound 3, concentration for 50% growth inhibition: 43700 nM
Estimate against measurement, compound 3: 2.2-fold (0.34 log units) below, within the range that was stated.
By their numbers in this assay, from the lowest: compound 1; then compounds 2 and 3 (each within the scatter of the next).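

In this assay, the change from carbamoyl to benzoyl gives a 1.1-fold higher number from compound 2 to compound 3 (0.04 log units; within the scatter) so a phenyl placed directly on this carbonyl carbon does not separate from the amino group. The phenyl in place of (4-chlorophenyl)amino gives a 2.5-fold higher number from compound 1 to compound 3 (0.39 log units; beyond the scatter) and leaves compound 1 with the lowest number of the three, so a phenyl alone on the carbonyl carbon does not reproduce its value. Nothing available explains these results.

On these data alone, whether a plain phenylamino group would match compound 1 remains open. So does the reading of a methyl ester or a carboxylic acid at this carbonyl carbon.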